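Working notes: 2-fluorophenyl in place of 4-carbamoylphenyl

This account rests on a few compounds, and the source may have more. Where it says the series, first, only, none or still open, it means among the compounds named here.

Values in a functional assay on Jurkat cells (Homo sapiens); a lower number here means a stronger inhibitor, a higher number a weaker inhibitor
- compound 1 `CC(C)[C@H](NC(=O)COc1cccc2ccccc12)C(=O)N[C@@H](CC(=O)O)C(=O)COc1cccc2ccccc12` gives > 100000 nM (a limit)
- compound 2 `CC(C)[C@H](NC(=O)COc1cccc2ccccc12)C(=O)N[C@@H](CC(=O)O)C(=O)COc1cccc(C(F)(F)F)c1` gives > 100000 nM (a limit)
- compound 3 `CC(C)[C@H](NC(=O)COc1cccc2ccccc12)C(=O)N[C@@H](CC(=O)O)C(=O)COc1ccc(C(N)=O)cc1` gives > 100000 nM (a limit)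

Compound 3 stands at a limit, not at a number, and so do both other compounds: the limit of > 100000 nM in this assay, at which 3 of the 3 values shown sit. Compound 4 `CC(C)[C@H](NC(=O)COc1cccc2ccccc12)C(=O)N[C@@H](CC(=O)O)C(=O)COc1ccccc1F` carries 2-fluorophenyl in place of 4-carbamoylphenyl on an oxygen on a saturated carbon, with this difference: 2-fluorophenyl in place of 4-carbamoylphenyl on an oxygen on a saturated carbon. The measured steps at this place are a step that the two limits leave unreadable from compound 1 to compound 3 and a step that the two limits leave unreadable from compound 2 to compound 3, and also a step that the two limits leave unreadable from compound 1 to compound 2. None gives a size, so no shift in this assay is expected beyond the scatter, and another limit is the likeliest result. The expected step is a number no higher from compound 3 to compound 4 (the limit leaves the size open). The estimate for compound 4 is 100000 nM, with an expected range of 30000 nM to 300000 nM.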

Compound 4, half-maximal inhibitory concentration: > 100000 nM
Compound 4 ended at the assay's limit; the forecaster's own chance of this, stated with the estimate: 80%; the middle value lies on the limit itself.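

In this assay compound 4 gives > 100000 nM, a limit, so its steps to compound 1, compound 2 and compound 3 cannot be read. The compounds shown leave open whether any group at this place changes inhibition: the limit of > 100000 nM in this assay, at which 4 of the 4 values shown sit.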